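Removing the ethoxycarbonyl group from a triazole sulfide

A few compounds are considered here, and "the series" means these few. Any claim that something is new, unique, unknown or untested is made for them only; others in the source may bear on it.

The series shares one core, seen in compound 1 `CCCSc1nnc(COc2ccccc2C2=NOC(c3ccc(Cl)cc3Cl)C2)n1NC(=O)CCl`, which carries a propylsulfanyl group and in an ADME assay (MDM cells, Homo sapiens) for cytotoxicity, read by resazurin assay, with a stated time of 3 days (a higher number here means a weaker inhibitor, a lower number a stronger inhibitor), gives 28.7 ug/mL. Within the data shown here, compound 2 `CCOC(=O)CSc1nnc(COc2ccccc2C2=NOC(c3ccc(Cl)cc3Cl)C2)n1NC(=O)CCl` bears an (ethoxycarbonyl)methyl group on the sulfur instead, and in this assay compound 2 gives "not determined" (no result reported), so no single number stands for it and no step from it can be reckoned. Compound 3 `CSc1nnc(COc2ccccc2C2=NOC(c3ccc(Cl)cc3Cl)C2)n1NC(=O)CCl` is the methylsulfanyl member. Its relation to compound 2 is hydrogen in place of ethoxycarbonyl on a saturated chain carbon bound to a sulfur. Since compound 2 gives no number, only compound 1 offers a foothold, and its chain differs from that of compound 3 by length alone. For compound 3 a step in this assay no larger than the scatter, in either direction, is expected. Compound 3 is thus estimated at 30 ug/mL, with a likely range from 12 ug/mL to 75 ug/mL.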

Compound 3, half-maximal inhibitory concentration: 2.7 ug/mL
Compound 3: the middle estimate sits 11-fold (1.05 log units) above what was measured; the whole stated range lies above it.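

In this assay, shortening propylsulfanyl to methylsulfanyl gives an 11-fold lower number from compound 1 to compound 3 (1.03 log units; beyond the scatter), so this position responds strongly to the length of the chain on the sulfur, which a single measured compound could not show. The step from compound 2 to compound 3 cannot be read, as compound 2 has no number, so the loss of ethoxycarbonyl itself remains unmeasured here. No measurement shown gives a reason for the size of the step from propylsulfanyl to methylsulfanyl.

As far as these compounds go, only the methyl and propyl chains carry numbers here, so it remains open whether an ethyl chain would read with compound 3, with compound 1 or somewhere in between, and how a longer chain such as butyl would behave. From the compounds shown here alone, it is equally open what a carboxylic acid or an amine at the end of the sulfur chain would do to the reading.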